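From phenyl to 4-methylphenyl in compound 1

This account rests on a few compounds, and the source may have more. Where it says the series, first, only, none or still open, it means among the compounds named here.

Values so far in a physicochemical assay for lipophilicity, at pH 5.2; a higher number here means a more lipophilic compound, a lower number a more polar compound
Compound 1 `Cc1c(CN2CCCC2)cc(-c2ccccc2)n1Nc1ccnc2cc(Cl)ccc12` gives 3.28
Compound 2 `Cc1c(CN2CCCC2)cc(-c2ccc(Cl)cc2)n1Nc1ccnc2cc(Cl)ccc12` gives 4.06
Compound 3 `Cc1c(CN2CCCC2)cc(-c2ccc(F)cc2)n1Nc1ccnc2cc(Cl)ccc12` gives 3.45

Compound 1 shares the low end of this small set with compound 3, and compound 2 stands clear of both. Compound 4 `Cc1ccc(-c2cc(CN3CCCC3)c(C)n2Nc2ccnc3cc(Cl)ccc23)cc1` is not yet measured. It differs from compound 1 by methyl in place of hydrogen on an aromatic carbon. Two steps of the same kind bear on this: a number 0.78 log units higher from compound 1 to compound 2 (beyond the scatter) for chloro and a number 0.17 log units higher from compound 1 to compound 3 (within the scatter) for fluoro. Methyl has no measured step of its own, so a modest rise between those two is expected in this assay and probably nearer the chloro step. The expected change is a number 0.54 log units higher from compound 1 to compound 4 (beyond the scatter) as an estimate only. For compound 4 the estimated value is 3.82 with 3.5 to 4.15 as the expected range.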

Compound 4, distribution coefficient: 3.91
Beside the measured number, compound 4's estimate is 0.09 log units below it; the range from low to high includes it.
By their numbers in this assay, from the lowest: compounds 1 and 3 (each within the scatter of the next); then compounds 4 and 2 (each within the scatter of the next).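

Methyl is the third group on this aromatic carbon to be compared with hydrogen in this assay, and it too gives a higher number (a number 0.63 log units higher from compound 1 to compound 4 (beyond the scatter)). Methyl and chloro cannot be told apart here (a number 0.15 log units lower from compound 2 to compound 4 (within the scatter)), while methyl and fluoro can (a number 0.46 log units higher from compound 3 to compound 4 (beyond the scatter)). Nothing available explains these differences.

From the compounds shown here alone, what stays open is where an amine, a methoxy group or a longer chain such as ethyl would fall at this position. Going by these compounds, whether any such group would give a number lower than hydrogen also remains unknown.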